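Amide Swap Where Every Value Sits at the Limit

The compounds below may be only part of what the source reports. "The series", "measured", "known", "first", "only" and "open" are said of these compounds alone.

Compound 2 `COc1ccc2c(=O)c(/C=C/C(=O)Nc3cc(C)ccc3C)coc2c1` belongs to a small set built on a shared core. In a functional assay on L02 cells (Homo sapiens) for inhibition, read by MTT assay, with a stated time of 48 h (a higher number here means a weaker inhibitor, a lower number a stronger inhibitor), compound 2 gives > 200000 nM, which is a limit of the assay rather than a number. Compound 1 `O=C(/C=C/c1coc2cc(O)ccc2c1=O)NCc1ccccc1` gives > 200000 nM, likewise a limit. Compound 3 `COc1ccc(NC(=O)/C=C/c2coc3cc(O)ccc3c2=O)cc1` gives > 200000 nM, again a limit. Among the compounds with values here, the only measured step, a step that the two limits leave unreadable from compound 1 to compound 3, is therefore unreadable, because the limit of > 200000 nM in this assay, at which 3 of the 3 values shown sit, leaves no room for a readable difference. Compound 4 `COc1ccc2c(=O)c(/C=C/C(=O)Nc3ccc(Cl)cc3)coc2c1` differs from compound 2 by 4-chlorophenyl in place of 2,5-dimethylphenyl on an amide-type nitrogen. Within the data shown here, no measured step bears on this change. The step that the limit leaves unreadable from compound 2 to compound 4 is therefore expected to stay within the scatter, with another limit the most likely outcome. Compound 4 is expected to give 250000 nM, with a range from 100000 nM to 600000 nM.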

Compound 4, half-maximal inhibitory concentration: > 200000 nM
Compound 4 ended at the assay's limit (the forecaster's own chance of this, stated with the estimate: 85%); the middle value is on the limit's open side.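

No new step can be read between compound 2 and compound 4, because both results are limits: the limit of > 200000 nM in this assay, at which 4 of the 4 values shown sit.

The compounds shown leave open whether any change on the amide-type nitrogen would give a readable value in this assay.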